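Two Quinazoline Amines and a Swap on the Pyrrolidine

This account rests on a few compounds, and the source may have more. Where it says the series, first, only, none or still open, it means among the compounds named here.

Measured so far:
compound 1, `CC(C)c1ccc(O)c(-c2nc(N[C@H]3CCNC3)c3ccccc3n2)c1`: 1700 nM
compound 2, `CC(C)(O)[C@H]1C[C@H](Nc2nc(-c3cc(F)ccc3O)nc3ccccc23)CN1`: 460 nM

Both compounds were tested in an assay on isolated protein for inhibition of serine/threonine-protein kinase Chk2 (Homo sapiens); on this read-out higher numbers stand for weaker inhibition and lower numbers for stronger inhibition. Of the two numbers, compound 2 with 460 nM is the lower one, and its nearest neighbour is compound 1, whose 1700 nM lies beyond the usual scatter, so compound 2 counts as the stronger inhibitor of the pair.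

Compound 3, `OC[C@@H]1CNC[C@H]1Nc1nc(-c2cc(F)ccc2O)nc2ccccc12`, has not yet been measured. It keeps the shared core of compound 2 and differs in one place: 4-(hydroxymethyl)pyrrolidin-3-yl in place of 5-(1-hydroxy-1-methylethyl)pyrrolidin-3-yl on a nitrogen on an aromatic ring. Among the compounds with values here, no measured pair here tracks a change of this kind, so there is no step from which the size or direction can be read off; only the two measured values are known.

With nothing to anchor it, the expectation is for a modest shift away from compound 2, of about a 1.6-fold higher number from compound 2 to compound 3 (0.21 log units; within the scatter), with a wide range. Compound 3 is therefore estimated at 750 nM, expected to fall between 200 nM and 2800 nM in this assay.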

Compound 3, half-maximal inhibitory concentration: 37 nM
Compound 3: the middle estimate sits 20-fold (1.31 log units) above what was measured; measured number below the stated range.
By their numbers in this assay, from the lowest: compound 3; then compound 2; then compound 1.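

In this assay the group on a nitrogen on an aromatic ring proves to be a sensitive place: putting 4-(hydroxymethyl)pyrrolidin-3-yl in place of 5-(1-hydroxy-1-methylethyl)pyrrolidin-3-yl gives a 12-fold lower number from compound 2 to compound 3 (1.09 log units; beyond the scatter) in a single change. The two groups share a five-membered non-aromatic ring with one hetero atom and have the same counts of hydrogen-bond donors and acceptors, so those counts do not separate them; the visible differences are the size of the group, with 7 heavy atoms against 9, and the point on the ring that carries the hydroxyl-bearing chain. Nothing available here gives an explanation for a step of this size.

This one step changes the chain and its place on the ring together, so the compounds shown leave open which of the two matters more, or whether the step needs both. They also leave open whether an amine or a carboxylic acid in place of the hydroxyl, or a longer chain such as 2-hydroxyethyl, would keep the number this low.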